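The source may report more compounds than this note shows. Statements on the series, on what has been measured and on what is new or still open speak of the compounds shown alone.

Among the measured compounds shown here, compound 1, with the structure `COc1ccc(-c2c(C#N)c(N)c(C#N)c(SC)c2-c2ccc(OC)cc2)cc1`, is the only compound in this set with a number to its name. In an assay on isolated protein for inhibition of Maltase-glucoamylase (Homo sapiens), tested at 100 uM (on this read-out higher numbers stand for more inhibition at the one concentration tested (going by the name of the read-out) and lower numbers for less inhibition), compound 1 gives 14.4%, a modest degree of inhibition at the single concentration tested. Two related compounds carry no number at all. Compound 2, with the structure `CSc1c(C#N)c(N)c(C#N)c(C)c1-c1ccccc1F`, is reported in this assay as "not active" (no number reported), so no figure exists for it. Compound 3, with the structure `CSc1c(C#N)c(N)c(C#N)c(Cc2ccccc2)c1-c1ccccc1`, comes back in this assay as "not determined" (no result reported), so nothing is known of its behaviour. For the measured compounds named here, with only one figure, compound 1 stands alone, and no measured step exists to show how large a structural change moves this read-out.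

The unmeasured compound 4 has the structure `COc1ccc(-c2c(C)c(SC)c(C#N)c(N)c2C#N)cc1`. It differs from compound 1 in one place: methyl in place of 4-methoxyphenyl on an aromatic carbon. The change removes a sizeable aromatic group and leaves a single carbon in its stead, on the shared core.

Since compound 1 sits at a low level of inhibition, there is little room for a fall, and the step is expected to be small or within the scatter, with a slight lean downward: the step from compound 1 to compound 4 is expected to be a number 5.4 percentage points lower from compound 1 to compound 4 (within the scatter). For compound 4 the expected inhibition in this assay is 9%, within a range from 0% to 20%.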

Compound 4, a percentage reported as inhibition, at one concentration (the size of the read-out at that concentration, not a potency): 17.3%
The estimate for compound 4 lay 8.3 percentage points below the measured number; the measured number falls inside the stated range.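

In this assay, putting methyl in place of 4-methoxyphenyl on this aromatic carbon gives a number 2.9 percentage points higher from compound 1 to compound 4 (within the scatter), so the two compounds cannot be told apart on this read-out. Among the compounds shown here, this is the first measured step in the set, and it shows that a whole aromatic ring at this position can give way to a single carbon with no change that stands out from ordinary repeat-to-repeat variation. The modest inhibition seen with compound 1 therefore does not depend on the 4-methoxyphenyl group at this position, and nothing measured here gives a reason for that result.

The step says little about how this position behaves more widely, since both compounds sit low on the scale and a single swap cannot show whether any group here could raise inhibition well beyond the scatter. A carboxylic acid, an amine or a longer chain such as butyl on this aromatic carbon would test that more directly, as would replacing the methylsulfanyl group or the remaining 4-methoxyphenyl group on the shared core.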